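Removing Fluoro from a Weak Antiproliferative Compound

This account rests on a few compounds, and the source may have more. Where it says the series, first, only, none or still open, it means among the compounds named here.

In a functional assay on CCRF-CEM cells (Homo sapiens) for antiproliferative activity (a higher number here means a weaker inhibitor, a lower number a stronger inhibitor), compound 1 (`O=c1[nH]c(=O)n([C@@H]2C=C[C@H](CO)O2)cc1F`) gives 12900 nM. Compound 2 (`Nc1nc(=O)n(C2C=CC(CO)C2)cc1F`) is reported only as a limit, > 100000 nM. Compound 3 (`Nc1ccn(C2C=CC(CO)C2)c(=O)n1`) has hydrogen in place of fluoro on an aromatic carbon, (hydrogen in place of fluoro on an aromatic carbon). Going by the values given here, no measured pair isolates this change, so its size in this assay can only be expected, and no shift beyond the scatter is anticipated. Compound 3 is expected to stay weak, as compound 2 does at > 100000 nM. The expected change is a number no higher from compound 2 to compound 3 (the limit leaves the size open). For compound 3, the estimated value is 100000 nM, with an expected range of 30000 nM to 300000 nM.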

Compound 3, half-maximal inhibitory concentration: > 100000 nM
Compound 3 was reported as a limit; the forecaster's own chance of this, stated with the estimate: 60%; the middle value sits exactly at the limit.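

Compound 2 and compound 3 are each reported only as a limit, so no step can be read between them: the limit of > 100000 nM in this assay, at which 2 of the 3 values shown sit. The compounds shown leave open what size, if any, the change from fluoro to hydrogen has in this assay.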